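Acrylamide tail variation on a quinazoline-type antiproliferative series

This account rests on a few compounds, and the source may have more. Where it says the series, first, only, none or still open, it means among the compounds named here.

Measured compounds:
compound 1, `C=CC(=O)Nc1cc2c(N3CCc4ccccc43)ncnc2cc1OC`, 5580 nM in a functional assay on A549 cells (Homo sapiens) for antiproliferative activity, read by MTT assay, with a stated time of 72 h; on this read-out higher numbers stand for weaker inhibition and lower numbers for stronger inhibition
compound 2, `C/C=C/C(=O)Nc1cc2c(N3CCc4ccccc43)ncnc2cc1OC`, 8290 nM
compound 3, `COc1cc2ncnc(N3CCc4ccccc43)c2cc1NC(=O)/C=C/CN(C)C`, 2040 nM

Compound 3 gives the lowest number of the three. Going by the values given here, the step of a 2.7-fold lower number from compound 1 to compound 3 (0.44 log units; beyond the scatter) and the step of a 4.1-fold lower number from compound 2 to compound 3 (0.61 log units; beyond the scatter) both lie beyond the scatter, while a 1.5-fold higher number from compound 1 to compound 2 (0.17 log units; within the scatter) does not, so the amine-bearing tail of compound 3 is the one change that has so far moved the read-out.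

Compound 4, `COc1cc2ncnc(N3CCc4ccccc43)c2cc1NC(=O)/C=C/CN1CCCCC1`, keeps that tail but with piperidin-1-yl in place of dimethylamino on a saturated chain carbon bound to a double-bonded chain carbon. Among the compounds with values here, no measured pair in the set changes the amine itself, so the only guide is that the amine-bearing tail of compound 3 carries the gain seen in a 4.1-fold lower number from compound 2 to compound 3 (0.61 log units; beyond the scatter). A ring amine of the same kind keeps the basic nitrogen at the same place in the chain, so no step beyond the scatter is expected in either direction.

The estimate for compound 4 is 1800 nM, range 700 nM to 4500 nM, which would mean a step of a 1.1-fold lower number from compound 3 to compound 4 (0.05 log units; within the scatter) in this assay, expected to fall within the scatter.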

Compound 4, half-maximal inhibitory concentration: 2540 nM
The estimate for compound 4 lay 1.4-fold (0.15 log units) below the measured number, within the range that was stated.
By their numbers in this assay, from the lowest: compounds 3 and 4 (each within the scatter of the next); then compounds 1 and 2 (each within the scatter of the next).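

In this assay, piperidin-1-yl in place of dimethylamino on a saturated chain carbon bound to a double-bonded chain carbon gives a 1.2-fold higher number from compound 3 to compound 4 (0.10 log units; within the scatter), so the six-membered non-aromatic ring and its extra heavy atoms leave the read-out unresolved from that of the open amine. The amine-bearing tail also stays beyond the scatter against both amine-free tails, with a 3.3-fold lower number from compound 2 to compound 4 (0.51 log units; beyond the scatter) and a 2.2-fold lower number from compound 1 to compound 4 (0.34 log units; beyond the scatter), so across these two amines the change is not tied to dimethylamino alone. No measurement here accounts for the effect of either amine-bearing tail.

Open, from the compounds shown here alone, is whether morpholin-4-yl or 4-methylpiperazin-1-yl, with a second ring hetero atom, would hold the same level at this position. Also open, going by these compounds, is whether a longer chain carrying the amine would keep these steps.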